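Amine terminus swap on the thioether chain of the benzodiazepine-type series

The source may report more compounds than this note shows. Statements on the series, on what has been measured and on what is new or still open speak of the compounds shown alone.

Measured compounds in an assay on cells for inhibition of Voltage-dependent T-type calcium channel subunit alpha-1I (Homo sapiens), read by patch clamp, tested at 10 uM; a lower number here means less inhibition, a higher number more inhibition at the concentration tested (going by the name of the read-out):
compound 1 `O=C(CC1c2ccccc2N=C(SCCCCCN2CCCC2)N1c1ccc(-c2ccc(F)cc2)cc1)NCc1ccccc1` gives 68.2%
compound 2 `O=C(CC1c2ccccc2N=C(SCCCCCN2CCCC2)N1c1ccccc1)NCc1ccc(F)cc1` gives 22.1%
compound 3 `CN(C)CCCCCSC1=Nc2ccccc2C(CC(=O)NCc2ccccc2)N1c1ccccc1` gives 76%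

Compound 3 shows the highest of the three numbers, but its nearest neighbour, compound 1, sits within the scatter of it, so the two cannot be ordered. Compound 2 lies well below both, beyond the scatter, and is the only one of the three with a fluorine on the benzyl amide.

The unmeasured compound 4 `O=C(CC1c2ccccc2N=C(SCCCCCN2CCCC2)N1c1ccccc1)NCc1ccccc1` differs from compound 3 in one place: pyrrolidin-1-yl in place of dimethylamino on a saturated chain carbon, five bonds along the chain from a sulfur. Both ends of the change are a basic tertiary amine with one acceptor and no charge, and the chain from the sulfur keeps its length. The two measured compounds that already carry a pyrrolidin-1-yl at this position give very different numbers in this assay, so the amine terminus alone does not fix the read-out. For the measured compounds named here, no step between measured compounds isolates this change.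

Compound 4 is expected to stay close to compound 3, with a step of a number 14 percentage points lower from compound 3 to compound 4 (beyond the scatter) that is estimated to be within the scatter, perhaps slightly downward. Compound 4 is estimated at 62%, with a range from 32% to 85%.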

Compound 4, a percentage reported as inhibition, at one concentration (the size of the read-out at that concentration, not a potency): 78.3%
Compound 4: middle estimate off by 16.3 percentage points, on the low side, and the stated range covers the measured number.
By their numbers in this assay, from the lowest: compound 2; then compounds 1, 3 and 4 (each within the scatter of the next, the first and the last beyond it).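

In this assay, pyrrolidin-1-yl in place of dimethylamino on a saturated chain carbon, five bonds along the chain from a sulfur, gives a number 2.3 percentage points higher from compound 3 to compound 4 (within the scatter), so the two amine termini cannot be told apart at this position on this core. Compound 4 also makes the two earlier pyrrolidin-1-yl compounds readable one change at a time: hydrogen in place of fluoro on an aromatic carbon gives a number 56.2 percentage points higher from compound 2 to compound 4 (beyond the scatter), which places the large gap at the fluoro change and not at the amine terminus. Hydrogen in place of 4-fluorophenyl on an aromatic carbon gives a number 10.1 percentage points higher from compound 1 to compound 4 (beyond the scatter), a modest step next to the fluoro one.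

The compounds shown leave open whether other termini on the same chain, such as piperidin-1-yl, morpholin-4-yl or a primary amine, or a shorter chain, would hold the read-out at this level, and the read-out at one concentration gives no potency for any of them. Nothing available here offers a cause for any of these steps.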